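Amide to Urea at the Carbonyl Carbon

This account rests on a few compounds, and the source may have more. Where it says the series, first, only, none or still open, it means among the compounds named here.

Compound 1 `COc1cc(-c2nn(-c3cccc(NC(=O)c4cccc(C(F)(F)F)c4)c3)cc2-c2ccncc2)ccc1Cl` carries a 3-(trifluoromethyl)phenyl on the carbonyl carbon of its amide. In a functional assay on LOX IMVI cells (Homo sapiens) for inhibition, read by sulforhodamine B assay, with a stated time of 48 h (on this read-out lower numbers stand for higher toxicity in this test and higher numbers for lower toxicity in this test), compound 1 gives > 50000 nM, which is a limit of the assay and not a number. From the compounds shown here alone, compound 1 therefore sits at the limit of > 50000 nM in this assay, at which 1 of the 2 values shown sits, and its true place on the scale is unknown. Within the data shown here, compound 2 `O=C(Nc1cccc(-n2cc(-c3ccncc3)c(-c3ccc(Cl)c(O)c3)n2)c1)Nc1cc(C(F)(F)F)cc(C(F)(F)F)c1`, a urea that also differs from compound 1 in the aryl group and in a hydroxy in place of a methoxy, is the only compound with a number: in this assay compound 2 gives 2750 nM. Among the measured compounds shown here, no pair of measured compounds differs in one place, so no measured step is available.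

Compound 3 `COc1cc(-c2nn(-c3cccc(NC(=O)Nc4ccc(Cl)c(Cl)c4)c3)cc2-c2ccncc2)ccc1Cl` has not yet been measured. It differs from compound 1 in one place: (3,4-dichlorophenyl)amino in place of 3-(trifluoromethyl)phenyl on a carbonyl carbon. For the measured compounds named here, the data give no measured step for this change, so its size and direction cannot be read off; compound 2 shows only that a urea on the shared core reaches a number. Compound 3 is expected to give about 8000 nM, within a range of 1500 nM to 50000 nM. The estimated step from compound 1 to compound 3 is an at least 6.2-fold lower number from compound 1 to compound 3 (0.79 log units; beyond the scatter), toward a lower number, with the size uncertain since compound 1 offers only a limit.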

Compound 3, concentration lethal to 50% of the cells: > 50000 nM
Compound 3: a limit, no number; the forecaster's own chance of this, stated with the estimate: 25%; middle value at least 6.2-fold (0.79 log units) away from the limit.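

In this assay compound 3 gives > 50000 nM as a limit of the assay and not a number. Compound 1 also stands at a limit, so no step can be read between compound 1 and compound 3, and both share one position: the limit of > 50000 nM in this assay, at which 2 of the 3 values shown sit. The compounds shown leave open whether (3,4-dichlorophenyl)amino in place of 3-(trifluoromethyl)phenyl changes the value at all on the shared core.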